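The source may hold more compounds than are shown below. What is called first, only, known or untested is meant among the compounds shown, and "the series" means these compounds.

Compound 1 `O/N=C(\CCN1CCN(c2ccccn2)CC1)c1ccccc1` and compound 2 `N#Cc1cccnc1N1CCN(CC/C(=N\O)c2ccccc2)CC1` share one core. In a functional assay on HEK293 cells with D(4) dopamine receptor (Homo sapiens) as the target, read by FLIPR (on this read-out lower numbers stand for an effect already at smaller amounts and higher numbers for an effect only at larger amounts of compound), compound 1 gives 4.4 nM, and compound 2 gives 18 nM. The change between them is cyano in place of hydrogen on an aromatic carbon, and it made a 4.1-fold higher number from compound 1 to compound 2 (0.61 log units; beyond the scatter). Compound 3 `CCO/N=C(\CCN1CCN(c2ccccc2)CC1)c1ccccc1` is built on another core, and the difference between the two cores is not broken down here. In this assay compound 3 gives 109 nM, the highest number of the three. Compound 4 `CCO/N=C(\CCN1CCN(c2ccccc2C#N)CC1)c1ccccc1` has not yet been measured. It differs from compound 3 by cyano in place of hydrogen on an aromatic carbon. This is the same kind of change as that from compound 1 to compound 2, but not the same: in compound 2 the cyano sits on a six-membered aromatic ring with one nitrogen, two atoms from the ring nitrogen, whereas in compound 4 the ring is of carbon only. Resting on that earlier step, the expected step is a 3.2-fold higher number from compound 3 to compound 4 (0.51 log units; beyond the scatter), and compound 4 is estimated to give about 350 nM in this assay, with a likely range from 120 nM to 1000 nM.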

Compound 4, half-maximal effective concentration: 48.7 nM
The estimate for compound 4 lay 7.2-fold (0.86 log units) above the measured number; measured number below the stated range.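

In this assay the cyano change gave a 2.2-fold lower number from compound 3 to compound 4 (0.35 log units; beyond the scatter), which runs opposite to the earlier step. Set side by side, the two steps differ, so in this series neither the direction nor the size of the change carried from one core to the other: the same change on two cores in this assay, a 4.1-fold higher number (0.61 log units; beyond the scatter) from compound 1 to compound 2 and a 2.2-fold lower number (0.35 log units; beyond the scatter) from compound 3 to compound 4, 9.2-fold (0.96 log units) apart, beyond the scatter of two such steps This does not show which part of the cores accounts for the difference, and two steps cannot say how the change would behave on any further core.

The compounds shown leave open whether a methoxy group or a chlorine atom in place of the cyano would move the number the same way on both cores.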